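This account rests on a few compounds, and the source may have more. Where it says the series, first, only, none or still open, it means among the compounds named here.

Measured so far in a functional assay on the whole organism (heart) with Rattus norvegicus as the target; on this read-out lower numbers stand for an effect already at smaller amounts and higher numbers for an effect only at larger amounts of compound:
Compound 1 `CO/N=C(\C)C1CN2CCC1CC2`: > 0.32 mg/kg (a limit of the assay, not a number)
Compound 2 `CO/N=C(\F)C12CCCN(CC1)C2`: 0.024 mg/kg

For the measured compounds named here, compound 2 holds the only actual number on this scale, 0.024 mg/kg. Compound 1 reaches only a limit, > 0.32 mg/kg.

The next compound, compound 3 `CO/N=C(\Cl)C12CCCN(CC1)C2`, is compound 2 with one change: chloro in place of fluoro on a carbon with a double bond to nitrogen. In words, this is chloro in place of fluoro on a carbon with a double bond to nitrogen. Going by the values given here, no two measured compounds differ in one place only, so the data hold no direct example of what such a swap does in this assay. The best anchor is compound 2 with its 0.024 mg/kg, and exchanging one atom while the rest of the molecule stays the same suggests a small shift rather than a large one. A slight drift toward larger doses is the expected direction, although the change may well stay within the usual scatter. The expected move is a 1.3-fold higher number from compound 2 to compound 3 (0.10 log units; within the scatter). For compound 3 the estimate is 0.03 mg/kg, with an expected range of 0.008 mg/kg to 0.11 mg/kg.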

Compound 3, dose for half-maximal effect in the Rattus norvegicus assay: 0.24 mg/kg
Beside the measured number, compound 3's estimate is 8.0-fold (0.90 log units) below it; the whole stated range lies below it.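

For the compounds shown here, this is the first direct comparison, and it shows that the carbon with a double bond to nitrogen is far from indifferent to what it carries. In the Rattus norvegicus assay, chloro in place of fluoro gives a 10-fold higher number from compound 2 to compound 3 (1.00 log units; beyond the scatter), so compound 3 needs a clearly larger dose than compound 2 for the same half-maximal effect, even though the count of heavy atoms stays the same and neither group adds a hydrogen-bond donor or acceptor. The same exchange also separates the two compounds in a physicochemical assay for lipophilicity, measured as octanol-water partition, at pH 12 (on this read-out higher numbers stand for higher lipophilicity and lower numbers for lower lipophilicity), where compound 2 gives 1.01 and compound 3 gives 2.12, with compound 3 the more lipophilic of the pair: the measured distribution coefficient of compound 2, 1.01, and of compound 3, 2.12, a number 1.11 log units higher (beyond the scatter).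

With only this one pair, the shift in dose and the shift in lipophilicity occur together, but nothing shown can tie one to the other, since a link would need more compounds in which the group on this carbon changes while the rest stays the same. As far as these compounds go, it also remains open where a bromo group or a nitrile on a carbon with a double bond to nitrogen would fall on these two scales, and whether the two read-outs would keep moving together.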